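Swapping the pyrazole substituent on compound 2

A few compounds are considered here, and "the series" means these few. Any claim that something is new, unique, unknown or untested is made for them only; others in the source may bear on it.

Of the compounds shown here, three have been measured.
Compound 1, `NCCOc1cc(-c2cccnc2)ccc1C(N)=O`, gives 820 nM in an assay on cells for inhibition of MAP kinase-interacting serine/threonine-protein kinase 1 (Homo sapiens), read by mobility shift assay, with stated times of 10 min and 60 min, in the presence of a further agent that is not named here; on this read-out lower numbers stand for stronger inhibition and higher numbers for weaker inhibition.
Compound 2, `CC(C)Oc1cc(-c2cncc(-c3c[nH]nc3C3CC3)c2)ccc1C(N)=O`, gives 130 nM in this assay.
Compound 3, `CCNc1cc(-c2cccnc2)ccc1C(N)=O`, gives 58000 nM in this assay.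

Compound 2 stands with the lowest number of the three, which on this read-out means the strongest inhibition; compound 1 is nearest yet clearly apart, and compound 3 is furthest away. Compound 4, `CC(C)Oc1cc(-c2cncc(-c3cnn(C(C)C)c3)c2)ccc1C(N)=O`, has not been measured. It differs from compound 2 in one place: 1-isopropyl-1H-pyrazol-4-yl in place of 3-cyclopropyl-1H-pyrazol-4-yl on an aromatic carbon. As counted there, the group that leaves carries one hydrogen-bond donor, while the group that enters carries none and has two hydrogen-bond acceptors.

Among the compounds with values here, only one step between measured compounds is known, a 71-fold higher number from compound 1 to compound 3 (1.85 log units; beyond the scatter), and it concerns another aromatic carbon of the shared core; neither of those two compounds carries a pyrazole at all. Within the data shown here, no measured step therefore speaks directly to the change from compound 2 to compound 4. That single step shows that one change on this core can move the number a great deal, but its size cannot simply be carried over to a different place. The expectation is a modest step with wide uncertainty, leaning toward a higher number. Compound 4 is estimated to give 300 nM, between 80 nM and 1200 nM, an expected step of a 2.3-fold higher number from compound 2 to compound 4 (0.36 log units; beyond the scatter).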

Compound 4, half-maximal inhibitory concentration: 85 nM
Estimate against measurement, compound 4: 3.5-fold (0.55 log units) above, and the stated range covers the measured number.
By their numbers in this assay, from the lowest: compounds 4 and 2 (each within the scatter of the next); then compound 1; then compound 3.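

In this assay, the step of a 1.5-fold lower number from compound 2 to compound 4 (0.18 log units; within the scatter) lies within the scatter, so these two compounds cannot be ranked, although the group on this aromatic carbon has been rebuilt. The 3-cyclopropyl-1H-pyrazol-4-yl group has a three-membered carbon ring and a hydrogen-bond donor, whereas the 1-isopropyl-1H-pyrazol-4-yl group has neither, so, for this pair at least, neither feature is needed to keep the read-out in the same range. Within the data shown here, this is the first measured change at this position, and it shows a far smaller effect than the large step seen earlier elsewhere on the shared core, although that step cannot be carried over to this place. No measurement here explains why the two groups give such similar numbers.

The compounds shown leave open whether this tolerance extends to quite different groups on the pyrazole nitrogen, such as a longer chain ending in an amine or a carboxylic acid. They also leave open whether ethylamino in place of 2-aminoethoxy, tested only on compounds without a pyrazole, would cost as much on compounds that carry one.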